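Swapping fluoro for methoxy on the pendant phenyl ring

A few compounds are considered here, and "the series" means these few. Any claim that something is new, unique, unknown or untested is made for them only; others in the source may bear on it.

Of the compounds shown here, two have been tested so far in a functional assay on MCF7 cells (Homo sapiens) for antiproliferative activity, read by MTT assay, with a stated time of 48 h; on this read-out lower numbers stand for stronger inhibition and higher numbers for weaker inhibition. Compound 1 `Fc1ccc(-c2nn(-c3ccccc3)cc2-c2nc3ccccc3[nH]2)cc1` gives 3200 nM. For the measured compounds named here, compound 2 `COc1ccc2[nH]c(-c3cn(-c4ccccc4)nc3-c3ccc(F)cc3)nc2c1` gives 970 nM, the lower of the two numbers, and the single measured step, a 3.3-fold lower number from compound 1 to compound 2 (0.52 log units; beyond the scatter), sits beyond the scatter. Compound 3 `COc1ccc(-c2nn(-c3ccccc3)cc2-c2nc3cc(OC)ccc3[nH]2)cc1` differs from compound 2 in one place: methoxy in place of fluoro on an aromatic carbon. Going by the values given here, no measured step bears on this particular change; the only step seen concerns methoxy in place of hydrogen on an aromatic carbon elsewhere in the shared core, so it gives no direct guide here. With nothing pointing either way, the expectation for this assay is a step of a 1.0-fold higher number from compound 2 to compound 3 (0.01 log units; within the scatter), which lies within the scatter. Compound 3 is therefore estimated at 1000 nM, with a range from 400 nM to 2500 nM.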

Compound 3, half-maximal inhibitory concentration: 3130 nM
The estimate for compound 3 lay 3.1-fold (0.50 log units) below the measured number; measured number outside the range, above it.
By their numbers in this assay, from the lowest: compound 2; then compounds 3 and 1 (each within the scatter of the next).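

In this assay putting 4-methoxyphenyl where 4-fluorophenyl stood brings a 3.2-fold higher number from compound 2 to compound 3 (0.51 log units; beyond the scatter) and so shows that this position responds to the group it carries. For the compounds shown here, this is the first reading at this place, as the earlier step concerned a methoxy on the shared core: there, methoxy in place of hydrogen went with a lower number, while here methoxy in place of fluoro goes with a higher one, so the same group does not read alike at the two places. Nothing available explains this rise.

From the compounds shown here alone, it remains open how a plain phenyl, a chloro or a hydroxyl at this place would compare with the fluoro of compound 2. Also open, going by these compounds, is whether 4-methoxyphenyl gives a similar step on a core without its own methoxy.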